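A few compounds are considered here, and "the series" means these few. Any claim that something is new, unique, unknown or untested is made for them only; others in the source may bear on it.

Of the compounds shown here, two sharing one core have been measured so far. Compound 1 `O=C1Nc2ccc(Br)cc2/C1=N/NC(=S)N/N=C/c1c(F)cccc1Cl` gives 1610 nM in a functional assay on HeLa cells (Homo sapiens) for inhibition, read by MTT assay; a higher number here means a weaker inhibitor, a lower number a stronger inhibitor. Compound 2 `COc1ccc(/C=N/NC(=S)N/N=C2\C(=O)Nc3ccc(C)cc32)cc1O` gives 2730 nM in this assay. Among the measured compounds shown here, compound 1 stands lowest of these two numbers, with compound 2 its only neighbour, yet the gap between them lies within the usual scatter of repeated measurements, so the two cannot be told apart. Compound 3 `Cc1ccc(O)c(/C=N/NC(=S)N/N=C2\C(=O)Nc3ccc(Br)cc32)c1` has not yet been measured. It differs from compound 1 in one place: 2-hydroxy-5-methylphenyl in place of 2-chloro-6-fluorophenyl on a carbon with a double bond to nitrogen. For the measured compounds named here, no pair of measured compounds differing in exactly one place is available, so there is no measured step to lean on. Because compound 2, whose value 2730 nM sits within the scatter of compound 1, the change is expected to bring only a small step, a 1.2-fold higher number from compound 1 to compound 3 (0.09 log units; within the scatter), not clearly beyond the scatter. Compound 3 is therefore expected to give about 2000 nM, with a likely range from 800 nM to 5000 nM.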

Compound 3, half-maximal inhibitory concentration: > 50000 nM
Compound 3: no number, only a limit; the forecaster's own chance of this, stated with the estimate: 5%; middle value at least 25-fold (1.39 log units) away from the limit.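

Among the compounds shown here, at the aryl group on a carbon with a double bond to nitrogen, the earlier compounds gave no measured step, but this single change now gives one in this assay: 2-hydroxy-5-methylphenyl in place of 2-chloro-6-fluorophenyl brings an at least 31-fold higher number from compound 1 to compound 3 (1.49 log units; beyond the scatter). The two groups have the same heavy-atom count and each has one six-membered aromatic ring, so that count does not separate them; they differ in that chlorine and fluorine leave while a hydroxy group and a methyl group enter. The result for compound 3 is a limit, not a number, so the true size of the step remains unknown: the limit of > 50000 nM in this assay, at which 1 of the 3 values shown sits.

The compounds shown leave open whether the hydroxy group, the methyl group or the departure of the two halogens accounts for the step. They also leave open how a phenyl ring carrying an amine or a carboxylic acid would read here.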